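This account rests on a few compounds, and the source may have more. Where it says the series, first, only, none or still open, it means among the compounds named here.

Measured compounds and values: compound 1 `O=C(/C=C/c1cccc([N+](=O)[O-])c1)NNC(=O)c1ccc2c(c1)OCCO2` gives 1560 nM; compound 2 `O=C(/C=C/c1ccc(F)cc1)NNC(=O)c1ccc2c(c1)OCCO2` gives 990 nM; compound 3 `Cc1cccc(/C=C/C(=O)NNC(=O)c2ccc3c(c2)OCCO3)c1` gives 2890 nM, all in a functional assay on cells (Cancer cell lines, Homo sapiens) for inhibition, read by MTT assay, with a stated time of 48 h; a lower number here means a stronger inhibitor, a higher number a weaker inhibitor.

Compound 3 carries the highest of the three numbers in this assay, yet its gap to compound 1 stays within the scatter, and only its gap to compound 2 reaches beyond it (a 2.9-fold higher number from compound 2 to compound 3 (0.47 log units; beyond the scatter)). Compound 4 `O=C(/C=C/c1ccccc1[N+](=O)[O-])NNC(=O)c1ccc2c(c1)OCCO2` differs from compound 3 by 2-nitrophenyl in place of 3-methylphenyl on a double-bonded chain carbon bound to a double-bonded chain carbon. Among the compounds with values here, the one step that bears on this is the swap of nitro for methyl at the same place, which from compound 1 to compound 3 gave a 1.9-fold higher number from compound 1 to compound 3 (0.27 log units; within the scatter). Reversing that trade, now with the nitro on a 2-nitrophenyl, is expected to lower the number by a similar modest amount, a 1.8-fold lower number from compound 3 to compound 4 (0.26 log units; within the scatter). For compound 4 the estimate is 1600 nM, ranging from 600 nM to 4500 nM.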

Compound 4, half-maximal inhibitory concentration: 890 nM
Beside the measured number, compound 4's estimate is 1.8-fold (0.25 log units) above it; the measured number falls inside the stated range.
By their numbers in this assay, from the lowest: compounds 4, 2, 1 and 3 (each within the scatter of the next, the first and the last beyond it).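

In this assay, within the data shown here, 2-nitrophenyl gives a clear step away from 3-methylphenyl (a 3.2-fold lower number from compound 3 to compound 4 (0.51 log units; beyond the scatter)), the first nitro-for-methyl exchange here to pass the scatter. Against the other two groups, no separation appears (a 1.1-fold lower number from compound 2 to compound 4 (0.05 log units; within the scatter); a 1.8-fold lower number from compound 1 to compound 4 (0.24 log units; within the scatter)), so 2-nitrophenyl, 4-fluorophenyl and 3-nitrophenyl cannot be ranked at this place. No measurement available here explains these results.

Still open, going by these compounds, is how 2-methylphenyl would compare, which would show whether the group or its ring position matters more. Also open, on these data alone, is whether an aminophenyl or a carboxyphenyl group would hold this level.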